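The source may hold more compounds than are shown below. What is called first, only, known or untested is meant among the compounds shown, and "the series" means these compounds.

Compound 1 `COc1ncnc2c1c(-c1ccsc1)cn2[C@@H]1O[C@H](CO)[C@@H](O)[C@H]1O` is the reference point. In a functional assay on A549 cells (Homo sapiens), read by MTT assay, with a stated time of 72 h (on this read-out lower numbers stand for stronger inhibition and higher numbers for weaker inhibition), compound 1 gives 5170 nM, the lowest of the two plain numbers shown. The nearest is compound 3 `C#Cc1cn([C@@H]2O[C@H](CO)[C@@H](O)[C@H]2O)c2ncnc(C)c12`, which in this assay gives 19200 nM. Going by the values given here, compound 2 `CN(C)c1ncnc2c1c(-c1ccsc1)cn2[C@@H]1O[C@H](CO)[C@@H](O)[C@H]1O` reaches only a limit of the assay, > 20000 nM; the one measured step, an at least 3.8-fold higher number from compound 1 to compound 2 (0.58 log units; beyond the scatter), changes a different part of the core from the one at issue here (the limit of > 20000 nM in this assay, at which 1 of the 3 values shown sits).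

Compound 4 `COc1ncnc2c1c(-c1ccoc1)cn2[C@@H]1O[C@H](CO)[C@@H](O)[C@H]1O` differs from compound 1 by furan-3-yl in place of thiophen-3-yl on an aromatic carbon. Among the compounds with values here, no measured step touches this exchange, so the expectation is a step within the usual scatter. The step of a 1.2-fold higher number from compound 1 to compound 4 (0.06 log units; within the scatter) is the estimated outcome. Compound 4 is expected to give 6000 nM, with a range from 2500 nM to 15000 nM.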

Compound 4, half-maximal inhibitory concentration: 1160 nM
The estimate for compound 4 lay 5.2-fold (0.71 log units) above the measured number; the measured number lies below the stated range.
By their numbers in this assay, from the lowest: compound 4; then compound 1; then compound 3. At a limit, above all of these: compound 2.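

Swapping thiophen-3-yl for furan-3-yl at this aromatic carbon, two ring bonds from the ring nitrogen, gives in this assay a 4.5-fold lower number from compound 1 to compound 4 (0.65 log units; beyond the scatter) and shows that this position responds to the ring's single hetero atom. Sulfur gives way to oxygen while the methoxy group and the rest of the shared core stay the same. Nothing measured here bears on why the oxygen-containing ring gives the lower number.

The compounds shown leave open how a phenyl or pyrrole ring would behave at this position. They also leave open whether furan-3-yl would give a similar step with dimethylamino in place of methoxy.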